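This account rests on a few compounds, and the source may have more. Where it says the series, first, only, none or still open, it means among the compounds named here.

In a functional assay on HCC 2998 cells (Homo sapiens) for antiproliferative activity (on this read-out lower numbers stand for stronger inhibition of growth and higher numbers for weaker inhibition of growth), the measured compounds read as follows.
compound 1 `COc1ccc(-c2nc3cc(F)ccc3s2)cc1OC` gives 0.25 nM
compound 2 `COc1cc(OC)cc(-c2nc3cc(F)ccc3s2)c1` gives 5210 nM
compound 3 `COc1cc(-c2nc3cc(F)ccc3s2)cc(OC)c1OC` gives 21100 nM

Compound 3 has the highest of these three numbers. Compound 4 `COc1cc(-c2nc3cc(F)ccc3s2)cc(O)c1OC` is not yet measured and carries hydrogen in place of methyl on an oxygen on an aromatic ring, methoxy to hydroxy (hydrogen in place of methyl on an oxygen on an aromatic ring). For the measured compounds named here, no measured step shows this change directly. The closest steps add a methoxy in place of hydrogen on an aromatic carbon, and they disagree in size: an 84000-fold higher number from compound 1 to compound 3 (4.93 log units; beyond the scatter) is large, while a 4.0-fold higher number from compound 2 to compound 3 (0.61 log units; beyond the scatter) is modest. Both move to a higher number, so a modest move to a lower number is expected, with wide uncertainty. The expected step is a 2.6-fold lower number from compound 3 to compound 4 (0.42 log units; beyond the scatter) in this assay on this estimate. The estimate for compound 4 is 8000 nM with 400 nM to 50000 nM as expected range.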

Compound 4, concentration for 50% growth inhibition: 6490 nM
Estimate against measurement, compound 4: 1.2-fold (0.09 log units) above, and the stated range covers the measured number.
By their numbers in this assay, from the lowest: compound 1; then compounds 2 and 4 (each within the scatter of the next); then compound 3.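

In this assay, methoxy to hydroxy on this oxygen gives a 3.3-fold lower number from compound 3 to compound 4 (0.51 log units; beyond the scatter) and is the first change shown at an oxygen rather than on an aromatic carbon. Adding hydroxy on an aromatic carbon of the core of compound 1 gives a 26000-fold higher number from compound 1 to compound 4 (4.41 log units; beyond the scatter) in this assay and leaves the hydroxy compound far from compound 1. No measurement here accounts for the size of either step. Still open, as far as these compounds go, is how an amine or an ethoxy group in place of this hydroxy would read in this assay.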